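A few compounds are considered here, and "the series" means these few. Any claim that something is new, unique, unknown or untested is made for them only; others in the source may bear on it.

Compound 3 `COc1ccc(-c2cc(-c3ccccc3)no2)c(OCCCN2CCCC2)c1` stands second highest of the three numbers in a functional assay on the whole organism (blood, strain Sprague-Dawley albino) with Rattus norvegicus as the target, with stated times of 30 min and 24 h, at a dose of 100 mg/kg by the oral route (a lower number here means less inhibition, a higher number more inhibition at the dose given (going by the name of the read-out)), where compound 3 gives 11.2%. Compound 1 `CCN(CC)CCCOc1cc(OC)ccc1-c1cc(-c2ccccc2)no1` gives 9.2% and compound 2 `COc1ccc(-c2cc(-c3ccccc3)no2)c(OCCCN2CCCCC2)c1` gives 15%; the steps of a number 2 percentage points higher from compound 1 to compound 3 (within the scatter) and a number 3.8 percentage points lower from compound 2 to compound 3 (within the scatter) both lie within the scatter, as does a number 5.8 percentage points higher from compound 1 to compound 2 (within the scatter). Compound 4 `CCCCN(C)CCCOc1cc(OC)ccc1-c1cc(-c2ccccc2)no1` has not yet been measured; it differs from compound 3 by butyl(methyl)amino in place of pyrrolidin-1-yl on a saturated chain carbon, three bonds along the chain from an oxygen on an aromatic ring. The step that bears most on it is the exchange of diethylamino for pyrrolidin-1-yl, because a number 2 percentage points higher from compound 1 to compound 3 (within the scatter) stayed within the scatter, so exchanging pyrrolidin-1-yl for butyl(methyl)amino is expected to give no step beyond the scatter, an expected a number 1.2 percentage points lower from compound 3 to compound 4 (within the scatter). For compound 4 the estimate in this assay is 10%, ranging from 2% to 20%.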

Compound 4, a percentage reported as inhibition, in the whole organism at one dose (the size of the read-out at that dose, not a potency): 14.2%
For compound 4 the middle estimate is 4.2 percentage points below the measured one; low and high end bracket the measured number.
By their numbers in this assay, from the lowest: compounds 1, 3, 4 and 2 (each within the scatter of the next).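

In this assay the steps of a number 3 percentage points higher from compound 3 to compound 4 (within the scatter) and a number 0.8 percentage points lower from compound 2 to compound 4 (within the scatter) and a number 5 percentage points higher from compound 1 to compound 4 (within the scatter) leave the open-chain butyl(methyl)amino level with the ringed pyrrolidin-1-yl and piperidin-1-yl and with diethylamino. Across these four compounds, then, neither a ring on the amine nor the change in heavy atoms gives a step beyond the scatter at this place on the saturated chain. Nothing measured here accounts for these numbers. Open, going by these compounds, is whether morpholine, piperazine or a primary amine at this place would step beyond the scatter, and whether a shorter or longer chain to the aromatic oxygen would do so.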